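The source may hold more compounds than are shown below. What is called first, only, known or untested is meant among the compounds shown, and "the series" means these compounds.

Measured in an in vitro ADME assay on microsomes from liver (Rattus norvegicus) for metabolic stability, read by LC-MS, tested at 1 uM; on this read-out higher numbers stand for fast clearance and lower numbers for slow clearance:
- compound 1, `CCCS(=O)(=O)c1cccc(C#Cc2cc(Cl)ccc2OCC(=O)O)c1`: < 10 mL.min-1.g-1
- compound 2, `COCCN(C)S(=O)(=O)c1ccc(C)c(C#Cc2cc(Cl)ccc2OCC(=O)O)c1`: 49 mL.min-1.g-1
- compound 3, `Cc1ccc(S(=O)(=O)N2CCOCC2)cc1C#Cc1cc(Cl)ccc1OCC(=O)O`: 10 mL.min-1.g-1

The value for compound 1 is a limit of this assay and not a number; it stands at the limit of < 10 mL.min-1.g-1 in this assay, at which 1 of the 3 values shown sits. Among the two numbers given, compound 2 holds the highest, with compound 3 the nearest: the change from compound 2 to compound 3 is a 4.9-fold lower number from compound 2 to compound 3 (0.69 log units; beyond the scatter), which puts morpholin-4-yl in place of (2-methoxyethyl)(methyl)amino on a sulfonyl sulfur.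

Compound 4, `Cc1ccc(S(=O)(=O)N2CCCCC2C)cc1C#Cc1cc(Cl)ccc1OCC(=O)O`, is not yet measured in this assay. It differs from compound 2 by 2-methylpiperidin-1-yl in place of (2-methoxyethyl)(methyl)amino on a sulfonyl sulfur. Within the data shown here, the one measured step that bears on it is the move from compound 2 to compound 3, where a six-membered ring on the sulfonyl sulfur replaced the same open (2-methoxyethyl)(methyl)amino group and gave a modest drop. The ring entering in compound 4 is 2-methylpiperidin-1-yl rather than morpholin-4-yl, so the step is expected to run in the same downward direction, though likely not as far. The step from compound 2 to compound 4 in this assay is therefore expected to be about a 2.5-fold lower number from compound 2 to compound 4 (0.39 log units; beyond the scatter). For compound 4 the expected value in this assay is 20 mL.min-1.g-1, within a range of 8 mL.min-1.g-1 to 50 mL.min-1.g-1.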

Compound 4, intrinsic clearance in microsomes: 418 mL.min-1.g-1
The estimate for compound 4 lay 21-fold (1.32 log units) below the measured number; measured number above the stated range.
By their numbers in this assay, from the lowest: compound 3; then compound 2; then compound 4.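

In this assay, a six-membered ring on the sulfonyl sulfur does not by itself set the direction of the change: the morpholin-4-yl swap gave a 4.9-fold lower number from compound 2 to compound 3 (0.69 log units; beyond the scatter), whereas the 2-methylpiperidin-1-yl swap at the same place gave an 8.5-fold higher number from compound 2 to compound 4 (0.93 log units; beyond the scatter). The identity of the ring therefore matters more here than the replacement of the open (2-methoxyethyl)(methyl)amino group, and the direct comparison of the two rings gives a 42-fold higher number from compound 3 to compound 4 (1.62 log units; beyond the scatter). The position on the sulfonyl sulfur thus tolerates a wide spread of clearance with the rest of the molecule unchanged, and nothing in the data at hand accounts for the rise.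

Still open, on these data alone, is which part of the change from morpholin-4-yl to 2-methylpiperidin-1-yl carries the step, the ring oxygen giving way to carbon or the added methyl; unsubstituted piperidin-1-yl and 2-methylmorpholin-4-yl on the same sulfonyl sulfur would separate the two. Also open, as far as these compounds go, is how a simple open amine such as diethylamino would sit relative to the (2-methoxyethyl)(methyl)amino group.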